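A Shorter, Branched Chain on the Amide Carbonyl

The source may report more compounds than this note shows. Statements on the series, on what has been measured and on what is new or still open speak of the compounds shown alone.

In a functional assay on HeLa cells (Homo sapiens) for antiproliferative activity, read by MTT assay, with a stated time of 72 h (a higher number here means a weaker inhibitor, a lower number a stronger inhibitor), compound 3 (`CCC/C=C/C(=O)Nc1cccc(Oc2nc(Nc3cccc(C#N)c3)nc3c2CSCC3)c1`) gives 7220 nM and lies within the scatter of compound 2 (`C/C=C/C(=O)Nc1cccc(Oc2nc(Nc3cccc(C#N)c3)nc3c2CSCC3)c1`) at 12800 nM on this scale. Compound 1 (`CC(C)=CC(=O)Nc1cccc(Oc2nc(Nc3ccn(C)n3)nc3c2CSCC3)c1`) returns only a limit of the assay at > 50000 nM and no number. Compound 4 (`CC(C)=CC(=O)Nc1cccc(Oc2nc(Nc3cccc(C#N)c3)nc3c2CSCC3)c1`) carries 2-methylprop-1-en-1-yl in place of pent-1-en-1-yl on a carbonyl carbon. Within the data shown here, the one measured step on this chain is a 1.8-fold lower number from compound 2 to compound 3 (0.25 log units; within the scatter) and it stays within the scatter. The expected step of a 1.4-fold higher number from compound 3 to compound 4 (0.14 log units; within the scatter) is therefore also no larger than the scatter. Among the measured compounds shown here, only two numbers bear on this chain, so the range stays wide. Compound 4 is expected near 10000 nM in this assay (estimated range 4500 nM to 24000 nM).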

Compound 4, half-maximal inhibitory concentration: 29200 nM
For compound 4 the middle estimate is 2.9-fold (0.47 log units) below the measured one, and the stated range ends below it.
By their numbers in this assay, from the lowest: compounds 3 and 2 (each within the scatter of the next); then compound 4. At a limit, above all of these: compound 1.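

The group on the carbonyl carbon does matter in this assay: with 2-methylprop-1-en-1-yl there is a 4.0-fold higher number from compound 3 to compound 4 (0.61 log units; beyond the scatter) and a 2.3-fold higher number from compound 2 to compound 4 (0.36 log units; beyond the scatter). Among these compounds, then, the branched chain separates from the two straight chains, prop-1-en-1-yl and pent-1-en-1-yl, which stay within the scatter of each other. Compound 1 stands at a limit and not a number, so 3-cyanophenyl in place of 1-methyl-1H-pyrazol-3-yl gives only a floor, an at least 1.7-fold lower number from compound 1 to compound 4 (0.23 log units; that floor lies within the scatter), because of that limit: the limit of > 50000 nM in this assay, at which 1 of the 4 values shown sits.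

Open still is how a longer chain or an amine on this chain would read here.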